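The source may report more compounds than this note shows. Statements on the series, on what has been measured and on what is new or still open speak of the compounds shown alone.

Of the compounds shown here, three built on one shared macrocyclic core have been tested in an ADME assay on Huh-7 cells (Homo sapiens) for cytotoxicity, read by colorimetric assay; a higher number here means that more compound is tolerated, a lower number that less compound is tolerated. Compound 1 `COc1ccc2c(O[C@H]3C[C@H]4C(=O)N(C)CCCC/C=C/[C@@H]5C[C@@]5(C(=O)NS(=O)(=O)C5(C)CC5)NC(=O)N4C3)cc(-c3cc(C(C)C)on3)nc2c1Cl` gives 75000 nM. Compound 2 `COc1ccc2c(O[C@H]3C[C@H]4C(=O)N(C)CCCC/C=C/[C@@H]5C[C@@]5(C(=O)NS(=O)(=O)C5(C)CC5)NC(=O)N4C3)cc(-c3csc(C(F)(F)F)n3)nc2c1Cl` gives 59000 nM. Compound 3 `COc1ccc2c(O[C@H]3C[C@H]4C(=O)N(C)CCCC/C=C/[C@@H]5C[C@@]5(C(=O)NS(=O)(=O)C5(C)CC5)NC(=O)N4C3)cc(-n3cc(C(C)C)cn3)nc2c1C` differs from compound 2 in two places rather than one; compound 3 gives 9610 nM. On these numbers compound 2 stands second highest of the three: compound 1 is its nearest neighbour, with a gap that lies within the usual scatter, while compound 3 is furthest away, with a gap that lies well beyond it.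

Compound 4 `C=Cc1csc(-c2cc(O[C@H]3C[C@H]4C(=O)N(C)CCCC/C=C/[C@@H]5C[C@@]5(C(=O)NS(=O)(=O)C5(C)CC5)NC(=O)N4C3)c3ccc(OC)c(Cl)c3n2)n1` has not yet been measured in this assay. It differs from compound 2 in one place: 4-vinyl-1,3-thiazol-2-yl in place of 2-(trifluoromethyl)-1,3-thiazol-4-yl on an aromatic carbon. Within the data shown here, one measured step bears on this kind of change, an exchange of one five-membered aromatic group for another on the same aromatic carbon: a 1.3-fold lower number from compound 1 to compound 2 (0.10 log units; within the scatter). That step stayed inside the scatter. Compound 3 also carries a different five-membered ring, but its second change on the shared core means its number cannot be tied to the ring alone. The step from compound 2 to compound 4 is therefore expected to be small, with no direction beyond the scatter, namely a 1.2-fold lower number from compound 2 to compound 4 (0.07 log units; within the scatter). Compound 4 is expected to give about 50000 nM, within a likely range from 20000 nM to 100000 nM.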

Compound 4, half-maximal cytotoxic concentration: 57100 nM
Estimate against measurement, compound 4: 1.1-fold (0.06 log units) below; low and high end bracket the measured number.
By their numbers in this assay, from the lowest: compound 3; then compounds 4, 2 and 1 (each within the scatter of the next).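

In this assay, the aromatic carbon next to the ring nitrogen has now taken a third five-membered aromatic group, and the number holds: the exchange of 2-(trifluoromethyl)-1,3-thiazol-4-yl for 4-vinyl-1,3-thiazol-2-yl gives a 1.0-fold lower number from compound 2 to compound 4 (0.01 log units; within the scatter) and the exchange of 5-isopropyl-1,2-oxazol-3-yl for the same vinyl thiazole gives a 1.3-fold lower number from compound 1 to compound 4 (0.12 log units; within the scatter) and both steps stay within the scatter. The earlier step only swapped one ring for another, whereas this one keeps the thiazole ring, attaches it through a different ring carbon, and replaces trifluoromethyl with vinyl, so the tolerance seen so far survives a change in how the ring is joined and in what it carries. Nothing at hand gives a reason for this flat result.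

All the groups shown at this position are five-membered aromatic rings, so it remains open how an amine, a carboxylic acid or a six-membered aromatic ring such as pyridine would read there. Also open, as far as these compounds go, is which of the two differences in compound 3 goes with its 9610 nM reading.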